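The source may report more compounds than this note shows. Statements on the series, on what has been measured and on what is new or still open speak of the compounds shown alone.

Measured so far in a functional assay on A549 cells (Homo sapiens) for cytotoxicity, read by MTT assay, with a stated time of 24 h; on this read-out higher numbers stand for weaker inhibition and lower numbers for stronger inhibition:
compound 1 `Cc1ncc([N+](=O)[O-])n1CCOc1ccccc1` — 107 ug/mL
compound 2 `Cc1ncc([N+](=O)[O-])n1CCOc1ccc([N+](=O)[O-])cc1` — 110 ug/mL

Compound 1 gives the lower of the two numbers; compound 2 at 110 ug/mL sits within the scatter of it, the step being a 1.0-fold higher number from compound 1 to compound 2 (0.01 log units; within the scatter). Compound 3 `Cc1ncc([N+](=O)[O-])n1CCOc1cccc([N+](=O)[O-])c1` differs from compound 1 by nitro in place of hydrogen on an aromatic carbon. For the measured compounds named here, the only measured step bearing on this change is that same nitro addition, a 1.0-fold higher number from compound 1 to compound 2 (0.01 log units; within the scatter), which did not move the number beyond the scatter. For compound 3 no step beyond the scatter is therefore expected, a 1.0-fold higher number from compound 1 to compound 3 (0.00 log units; within the scatter). Compound 3 is estimated at 108 ug/mL, expected range 70 ug/mL to 170 ug/mL.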

Compound 3, half-maximal inhibitory concentration: 108 ug/mL
The estimate for compound 3 equals the measured number at the digits printed; the measured number falls inside the stated range.
By their numbers in this assay, from the lowest: compounds 1, 3 and 2 (each within the scatter of the next).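

In this assay, nitro on an aromatic carbon meta to a large group gives a 1.0-fold higher number from compound 1 to compound 3 (0.00 log units; within the scatter). Nitro in place of hydrogen has now been read at two places on the six-membered aromatic ring, in compound 2 and compound 3, and neither step leaves the scatter. No evidence on hand bears on why this change leaves the number in place.

From the compounds shown here alone, whether an amine or a carboxylic acid on the same aromatic carbon would move the number stays open. So does the effect of a longer chain linking the shared core to the aromatic ring.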